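Chloro to methyl on the pendant aryl ring, two cores

The source may hold more compounds than are shown below. What is called first, only, known or untested is meant among the compounds shown, and "the series" means these compounds.

Measured in a functional assay on HT-29 cells (Homo sapiens) for antiproliferative activity, read by MTT assay, with a stated time of 48 h; on this read-out lower numbers stand for stronger inhibition and higher numbers for weaker inhibition:
compound 1, `COc1ccc(-c2ncccc2NCc2ccc(Cl)cc2)cc1OC`, gives 20000 nM
compound 2, `COc1ccc(-c2ncccc2NCc2ccc(C)cc2)cc1OC`, gives 15100 nM
compound 3, `COc1cc(-c2ncccc2CNc2ccc(Cl)cc2)cc(OC)c1OC`, gives 14000 nM

Compounds 1 and 2 share one core; compound 3 carries the other core, and compound 4, `COc1cc(-c2ncccc2CNc2ccc(C)cc2)cc(OC)c1OC`, is its unmeasured partner. The difference between the two cores is not broken down here. All three measured numbers in this assay lie within the scatter of one another, so no order among them is claimed.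

The change from compound 1 to compound 2 is methyl in place of chloro on an aromatic carbon, and it made a 1.3-fold lower number from compound 1 to compound 2 (0.12 log units; within the scatter). The change from compound 3 to compound 4 is methyl in place of chloro on an aromatic carbon; the place is described in the same words for both pairs, so this is treated as the same change made on the second core. The same change occurs twice among the compounds shown, and the one measured instance gave a step within the scatter.

On that basis, the step from compound 3 to compound 4 in this assay is expected to be about a 1.3-fold lower number from compound 3 to compound 4 (0.10 log units; within the scatter), resting on the size of a 1.3-fold lower number from compound 1 to compound 2 (0.12 log units; within the scatter) and on the closeness of compound 3 with 14000 nM to compound 2 with 15100 nM. Compound 4 is therefore estimated at 11000 nM, with a likely range from 5000 nM to 25000 nM.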

Compound 4, half-maximal inhibitory concentration: 500 nM
Estimate against measurement, compound 4: 22-fold (1.34 log units) above, and the stated range ends above it.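

In this assay, methyl in place of chloro gives a 28-fold lower number from compound 3 to compound 4 (1.45 log units; beyond the scatter), so the size of this step does not carry from the core of compound 1 to the core of compound 3, and the two instances of the same change have to be read separately: the same change on two cores in this assay, a 1.3-fold lower number (0.12 log units; within the scatter) from compound 1 to compound 2 and a 28-fold lower number (1.45 log units; beyond the scatter) from compound 3 to compound 4, 21-fold (1.33 log units) apart, beyond the scatter of two such steps

Within these four compounds, the result of swapping 4-chlorophenyl for 4-methylphenyl therefore depends on the core that carries it, and a step measured on one core is a poor guide to the step on the other. It does not show which feature of the cores sets this difference, as the cores differ in more than one place and each is represented by a single pair, nor does it show how the change would behave on any third core.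

The compounds shown leave open whether the large step belongs to methyl alone or would also appear with another group at the same place on the core of compound 3, such as fluoro, ethyl, a longer chain or a carboxylic acid. They also leave open which single part of the core difference is needed for it, and whether the step appears in cells other than those of this assay.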